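Thioester swap from compound 3 to compound 4

The source may report more compounds than this note shows. Statements on the series, on what has been measured and on what is new or still open speak of the compounds shown alone.

In a functional assay on HT-29 cells (Homo sapiens) for inhibition, read by MTT assay, with a stated time of 96 h (on this read-out higher numbers stand for weaker inhibition of growth and lower numbers for stronger inhibition of growth), compound 3 (`C=CCOC(=O)SCCCCCCNC(=O)c1cc(-c2ccncc2)n[nH]1`) gives 11900 nM and stands close to compound 1 (`O=C(OCc1ccccc1)SCCCCCCNC(=O)c1cc(-c2ccncc2)n[nH]1`) at 22000 nM within the scatter, shown by a 1.8-fold lower number from compound 1 to compound 3 (0.27 log units; within the scatter) here. Compound 2 (`CC(C)C(=O)SCCCCCCNC(=O)c1cc(-c2ccncc2)n[nH]1`) gives 25700 nM and differs slightly more, with a 2.2-fold lower number from compound 2 to compound 3 (0.33 log units; beyond the scatter) beyond the scatter. Among the measured compounds shown here, compound 4 (`CCCC(=O)SCCCCCCNC(=O)c1cc(-c2ccncc2)n[nH]1`) carries propyl in place of allyloxy on a carbonyl carbon as its one change. For the measured compounds named here, the nearest precedent is compound 2, which has isopropyl at that place, so a 2.2-fold lower number from compound 2 to compound 3 (0.33 log units; beyond the scatter) would run roughly in reverse, while a 1.2-fold higher number from compound 1 to compound 2 (0.07 log units; within the scatter) adds little. The expected result is a 1.8-fold higher number from compound 3 to compound 4 (0.27 log units; within the scatter) of modest size in this assay overall. For compound 4 the estimate is 22000 nM within a range of 10000 nM to 45000 nM as expected values.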

Compound 4, concentration for 50% growth inhibition: 12400 nM
For compound 4 the middle estimate is 1.8-fold (0.25 log units) above the measured one; low and high end bracket the measured number.
By their numbers in this assay, from the lowest: compounds 3, 4, 1 and 2 (each within the scatter of the next, the first and the last beyond it).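

In this assay, propyl in place of allyloxy on a carbonyl carbon whose other neighbour is sulfur stays within the scatter (a 1.0-fold higher number from compound 3 to compound 4 (0.02 log units; within the scatter)), so the allyloxy oxygen is not needed to hold this reading. Propyl in place of isopropyl gives a modest step beyond the scatter (a 2.1-fold lower number from compound 2 to compound 4 (0.32 log units; beyond the scatter)), so these two groups can be told apart here, while propyl in place of benzyloxy stays within it (a 1.8-fold lower number from compound 1 to compound 4 (0.25 log units; within the scatter)).

From the compounds shown here alone, whether a hexyl chain or a terminal amine at this place shifts the number further remains open. No available evidence explains these differences.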